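The source may report more compounds than this note shows. Statements on the series, on what has been measured and on what is new or still open speak of the compounds shown alone.

Working notes on the series. Compound 1 `CCn1c(-c2cnc(C)nc2)nc2c(O[C@H]3CCN(C(=O)C4CC4)C3)ncnc21` gives 1.3 h in an ADME assay (Canis lupus familiaris, strain Beagle) for metabolic stability (a higher number here means that the compound lasts longer, a lower number that the compound disappears faster), compound 2 `CCn1c(-c2ccc(C(F)(F)F)nc2)nc2c(O[C@H]3CCN(C(=O)c4cocn4)C3)ncnc21` gives 2.5 h, and compound 3 `CCn1c(-c2cnc(C)nc2)nc2c(O[C@H]3CCN(C(=O)C4CCC4)C3)ncnc21` gives 1.1 h. Of these three numbers compound 2 stands at the top, but its gap to compound 1 lies within the scatter and only its gap to compound 3 lies beyond it. Among the measured compounds shown here, the single measured step that touches the amide end of the molecule, a 1.2-fold lower number from compound 1 to compound 3 (0.07 log units; within the scatter), stays within the scatter.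

Compound 4 `CCn1c(-c2ccc(C(F)(F)F)nc2)nc2c(O[C@H]3CCN(C(=O)[C@H]4C[C@@H](OC)C4)C3)ncnc21` has not yet been measured in this assay. It differs from compound 2 by 3-methoxycyclobutyl in place of 1,3-oxazol-4-yl on a carbonyl carbon. For the measured compounds named here, no measured pair shows this exchange; the nearest comparison is the exchange of one small carbocycle for another in the same place, which moved the number little. On that basis no step beyond the scatter is expected from compound 2 to compound 4, and the expected step is a 1.3-fold lower number from compound 2 to compound 4 (0.10 log units; within the scatter). Compound 4 is therefore estimated at 2 h, with a range from 0.9 h to 4.5 h, pending the measurement.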

Compound 4, half-life: 2.6 h
Compound 4: the middle estimate sits 1.3-fold (0.11 log units) below what was measured, and the stated range covers the measured number.
By their numbers in this assay, from the lowest: compounds 3, 1, 2 and 4 (each within the scatter of the next, the first and the last beyond it).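

At this place, on a carbonyl carbon whose other neighbour is an amide-type nitrogen in a ring, replacing 1,3-oxazol-4-yl with 3-methoxycyclobutyl in this assay gives a 1.0-fold higher number from compound 2 to compound 4 (0.02 log units; within the scatter) and leaves the number within the scatter. The earlier step here, a 1.2-fold lower number from compound 1 to compound 3 (0.07 log units; within the scatter), exchanged only one carbocycle for another, whereas this pair shows that a five-membered aromatic ring with 2 hetero atoms and a four-membered non-aromatic ring of carbon only can also give numbers within the scatter of each other. The data shown offer nothing that explains this result.

From the compounds shown here alone, it remains open whether a carboxylic acid, an amine or a longer chain on this carbonyl carbon would also stay within the scatter. Also open, going by these compounds, is how 3-methoxycyclobutyl reads on the core of compound 1.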